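The compounds below may be only part of what the source reports. "The series", "measured", "known", "first", "only" and "open" are said of these compounds alone.

Two measured members of the series: compound 1 `COc1ccc(/C=C/C[C@H]2C[C@H]([C@H](O)c3ccc(OC)c(OC)c3)CO[C@@H]2c2ccc(OC)c(OC)c2)cc1OC` and compound 2 `O[C@@H](c1ccccc1)[C@H]1CO[C@H](c2ccccc2)[C@@H](C/C=C/c2ccccn2)C1`. In a functional assay on HL-60 cells (Homo sapiens) for cytotoxicity, read by WST assay, with a stated time of 48 h (on this read-out higher numbers stand for weaker inhibition and lower numbers for stronger inhibition), compound 1 gives 23500 nM, and compound 2 gives 36400 nM; the two numbers lie within the scatter of one another, so neither compound stands apart. Compound 3 `Cc1ccc(/C=C/C[C@H]2C[C@@H]([C@@H](O)c3ccccc3)CO[C@@H]2c2ccccc2)cc1C` is not yet measured. It differs from compound 2 by 3,4-dimethylphenyl in place of pyridin-2-yl on a double-bonded chain carbon bound to a double-bonded chain carbon. For the measured compounds named here, no measured pair carries this change, so the expected step of a 1.5-fold lower number from compound 2 to compound 3 (0.16 log units; within the scatter) is taken as none beyond the scatter. Compound 3 is estimated at 25000 nM, with a range from 8000 nM to 80000 nM.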

Compound 3, half-maximal inhibitory concentration: 9880 nM
Compound 3: middle estimate off by 2.5-fold (0.40 log units), on the high side; the measured number falls inside the stated range.
By their numbers in this assay, from the lowest: compound 3; then compounds 1 and 2 (each within the scatter of the next).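

Exchanging pyridin-2-yl for 3,4-dimethylphenyl gives a 3.7-fold lower number from compound 2 to compound 3 (0.57 log units; beyond the scatter) in this assay, a step beyond the scatter. For the compounds shown here, this is the first single change read, and it shows that the number responds to what this position carries. No data at hand explain the step. On these data alone, it remains open whether the step follows the loss of the ring nitrogen or the entry of the two methyl groups. Plain phenyl at this place would separate the two, and a carboxylic acid on this ring is a further open case.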